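The source may report more compounds than this note shows. Statements on the series, on what has been measured and on what is new or still open speak of the compounds shown alone.

Measured so far:
- compound 1 `O=[N+]([O-])c1c(CS(=O)(=O)c2ccccc2)nc2c(C#Cc3ccccc3F)cc(Cl)cn12`: > 3900 nM (a limit)
- compound 2 `CC(O)(C#Cc1cc(Cl)cn2c([N+](=O)[O-])c(CS(=O)(=O)c3ccccc3)nc12)c1ccccc1`: 18800 nM

Within the data shown here, in an ADME assay on HepG2 cells (Homo sapiens) for cytotoxicity, read by MTT assay, with a stated time of 72 h (on this read-out lower numbers stand for higher toxicity in this test and higher numbers for lower toxicity in this test), compound 2 gives 18800 nM, the only actual number. The value of compound 1 is > 3900 nM, which is a limit. Compound 3 `O=[N+]([O-])c1c(CS(=O)(=O)c2ccccc2)nc2c(C#CCO)cc(Cl)cn12` carries hydroxymethyl in place of 1-hydroxy-1-phenylethyl on a triple-bonded carbon. Among the measured compounds shown here, the only measured step is a step that the limit leaves unreadable from compound 1 to compound 2, and its size cannot be read because of the limit of > 3900 nM in this assay, at which 1 of the 2 values shown sits. The expectation therefore rests on compound 2 at 18800 nM, with no step beyond the scatter expected in this assay: a 1.3-fold higher number from compound 2 to compound 3 (0.12 log units; within the scatter). The estimate for compound 3 is 25000 nM, with an expected range of 8000 nM to 70000 nM.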

Compound 3, half-maximal cytotoxic concentration: 10100 nM
Beside the measured number, compound 3's estimate is 2.5-fold (0.39 log units) above it; the measured number falls inside the stated range.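

On the triple-bonded carbon, hydroxymethyl in place of 1-hydroxy-1-phenylethyl removes the six-membered aromatic ring, and this assay gives a 1.9-fold lower number from compound 2 to compound 3 (0.27 log units; within the scatter). Among these compounds, this is the first readable step at this position, and the read-out does not separate these two groups. Compound 1 stands at a limit, and the steps from it cannot be read: the limit of > 3900 nM in this assay, at which 1 of the 3 values shown sits.

Still open, as far as these compounds go, is whether an amine or a carboxylic acid on the triple-bonded carbon would move the number beyond the scatter in this assay. The same question holds for a longer chain carrying a terminal hydroxyl.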